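A few compounds are considered here, and "the series" means these few. Any claim that something is new, unique, unknown or untested is made for them only; others in the source may bear on it.

Measured compounds:
- compound 1, `O=C(Nc1nc2ccc(Cl)cc2s1)c1cn(-c2ccccc2)nc1-c1ccccc1`, 4980 nM in a functional assay on U-87MG ATCC cells for cytotoxicity against U-87 MG (Homo sapiens), read by MTT assay, with a stated time of 72 h; on this read-out lower numbers stand for stronger inhibition and higher numbers for weaker inhibition
- compound 2, `O=C(Nc1nc2ccc(Cl)cc2s1)c1cn(-c2ccccc2)nc1-c1ccc(F)cc1`, 6770 nM in this assay
- compound 3, `COc1ccc(-c2nn(-c3ccccc3)cc2C(=O)Nc2nc3ccc(F)cc3s2)cc1`, 8990 nM in this assay

All three numbers in this assay lie close together. Compound 3 gives 8990 nM, and its distance to compound 2 and to compound 1 is within the scatter in both cases, so no order among the three is established.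

Compound 4, `COc1ccc(-c2nn(-c3ccccc3)cc2C(=O)Nc2nc3ccc(Cl)cc3s2)cc1`, differs from compound 3 by chloro in place of fluoro on an aromatic carbon, placed on an aromatic carbon of a six-membered aromatic ring of carbon only, part of a fused or bridged system of two rings. Within the data shown here, no measured step matches this change: compound 1 and compound 3 both carry their halogens on this ring but also differ elsewhere, so their two values can only be noted side by side and not read as a step. Among the measured compounds shown here, the only measured single change, a 1.4-fold higher number from compound 1 to compound 2 (0.13 log units; within the scatter), is a halogen change on a different ring and stayed within the scatter. On that basis no step beyond the scatter is expected in this assay from compound 3 to compound 4.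

Compound 4 is therefore expected at 7000 nM, with a range of 3000 nM to 16000 nM, meaning an estimated step of a 1.3-fold lower number from compound 3 to compound 4 (0.11 log units; within the scatter).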

Compound 4, half-maximal inhibitory concentration: 8710 nM
Beside the measured number, compound 4's estimate is 1.2-fold (0.09 log units) below it; measured number inside the range.
By their numbers in this assay, from the lowest: compounds 1, 2, 4 and 3 (each within the scatter of the next).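

In this assay, among these compounds, the change from 6-fluoro-1,3-benzothiazol-2-yl to 6-chloro-1,3-benzothiazol-2-yl gives a 1.0-fold lower number from compound 3 to compound 4 (0.01 log units; within the scatter), the first reading of a single change at this position, so the exchange of these two halogens on the fused system leaves no measurable mark here. Among the compounds shown here, compound 4 also gives the first readings for methoxy at the other varied site with chloro held constant: methoxy in place of fluoro gives a 1.3-fold higher number from compound 2 to compound 4 (0.11 log units; within the scatter) and methoxy in place of hydrogen gives a 1.7-fold higher number from compound 1 to compound 4 (0.24 log units; within the scatter), so hydrogen, fluoro and methoxy at that site cannot be told apart in this small set. No supporting data bear on why these values stay so close together.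

Open, from the compounds shown here alone, is whether any group at the halogen position can move the number beyond the scatter, for instance an amine, a carboxylic acid or a longer chain such as butoxy in place of chloro. Also open, going by these compounds, is whether the same holds for the phenyl group that all four compounds share, where a substituent such as an amine or a nitrile could be read against compound 4.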